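Trifluoromethylbenzyl on the chlorophenyl amide

This account rests on a few compounds, and the source may have more. Where it says the series, first, only, none or still open, it means among the compounds named here.

In a functional assay on MCF7 cells (Homo sapiens) for antiproliferative activity, read by sulforhodamine B assay, with a stated time of 48 h (a higher number here means a weaker inhibitor of growth, a lower number a stronger inhibitor of growth), compound 2 `O=C(NCc1cn(Cc2ccc(F)cc2)nn1)c1cn(-c2ccccc2)nc1-c1ccc(Cl)cc1` gives 570 nM. Compound 1 `O=C(NCc1cn(Cc2ccc(C(F)(F)F)cc2)nn1)c1cn(-c2ccccc2)nc1-c1ccccc1` gives 840 nM in this assay; compound 2 has the smaller of the two numbers, with a gap to compound 1 that stays within the scatter. Compound 3 `O=C(NCc1cn(Cc2ccc(C(F)(F)F)cc2)nn1)c1cn(-c2ccccc2)nc1-c1ccc(Cl)cc1` differs from compound 2 by trifluoromethyl in place of fluoro on an aromatic carbon, the benzyl group compound 1 carries. Within the data shown here, no measured pair isolates this change, and compound 1 and compound 2 sit within the scatter of each other, so the expected step is a 1.1-fold higher number from compound 2 to compound 3 (0.06 log units; within the scatter), none beyond the scatter. Compound 3 is estimated at 650 nM, between 300 nM and 1400 nM.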

Compound 3, concentration for 50% growth inhibition: 4900 nM
Compound 3: middle estimate off by 7.5-fold (0.88 log units), on the low side, and the stated range ends below it.
By their numbers in this assay, from the lowest: compounds 2 and 1 (each within the scatter of the next); then compound 3.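

In this assay the change from 4-fluorobenzyl to 4-(trifluoromethyl)benzyl gives an 8.6-fold higher number from compound 2 to compound 3 (0.93 log units; beyond the scatter) and so shows that this position is not indifferent to the group it carries. With 4-(trifluoromethyl)benzyl held fixed, chloro in place of hydrogen gives a 5.8-fold higher number from compound 1 to compound 3 (0.77 log units; beyond the scatter) and so the high number appears, among these compounds, only where trifluoromethyl and chloro stand together. Nothing at hand explains either step.

Open, as far as these compounds go, is how a methoxy group or a carboxylic acid at this benzyl position would read. Also open, from the compounds shown here alone, is whether bromo in place of chloro would give a similar step.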